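Replacing the 4-propylpiperazin-1-yl side chain of compound 3

This account rests on a few compounds, and the source may have more. Where it says the series, first, only, none or still open, it means among the compounds named here.

In a functional assay on HCT-116 cells (Homo sapiens) for cytotoxicity, read by MTT assay, with a stated time of 72 h (a lower number here means a stronger inhibitor, a higher number a weaker inhibitor), compound 1 (`CN(C)CCCCCn1c2c(c3ccccc31)C(=O)c1c[n+]([O-])c3ccccc3c1C2=O`) gives 470 nM and compound 2 (`CN1CCN(CCCCn2c3c(c4ccccc42)C(=O)c2c[n+]([O-])c4ccccc4c2C3=O)CC1`) gives 10 nM on the same core. Compound 3 (`CCCN1CCN(CCCCn2c3c(c4ccccc42)C(=O)c2c[n+]([O-])c4ccccc4c2C3=O)CC1`) gives 790 nM in this assay and so lies level with one neighbour and far from the other: there is a 1.7-fold higher number from compound 1 to compound 3 (0.23 log units; within the scatter) but a 79-fold higher number from compound 2 to compound 3 (1.90 log units; beyond the scatter) in the same read-out.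

Compound 4 (`O=C1c2c[n+]([O-])c3ccccc3c2C(=O)c2c1c1ccccc1n2CCCN1CCC(O)CC1`) differs from compound 3 by 4-hydroxypiperidin-1-yl in place of (4-propylpiperazin-1-yl)methyl on a saturated chain carbon, three bonds along the chain from an aromatic nitrogen and this places 4-hydroxypiperidin-1-yl on a saturated chain carbon, three bonds along the chain from an aromatic nitrogen. Going by the values given here, no measured step makes this exchange. The nearest evidence is mixed: a 47-fold lower number from compound 1 to compound 2 (1.67 log units; beyond the scatter) shows a large move on changing the chain end, while a 1.7-fold higher number from compound 1 to compound 3 (0.23 log units; within the scatter) shows almost none. With compound 2 at 10 nM the measured numbers reach far lower than compound 3 does, so a moderate move downward is the likelier outcome.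

The expected change is a 4.0-fold lower number from compound 3 to compound 4 (0.60 log units; beyond the scatter) and it remains uncertain. For compound 4 the estimated value is 200 nM with an expected range from 40 nM to 900 nM.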

Compound 4, half-maximal inhibitory concentration: 190 nM
Compound 4: the middle estimate sits 1.1-fold (0.02 log units) above what was measured; low and high end bracket the measured number.
By their numbers in this assay, from the lowest: compound 2; then compound 4; then compounds 1 and 3 (each within the scatter of the next).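

In this assay, the 4-hydroxypiperidin-1-yl end, the only one shown with a hydrogen-bond donor, gives a clear gain over the propyl-bearing end, with a 4.2-fold lower number from compound 3 to compound 4 (0.62 log units; beyond the scatter), and also a gain over the dimethylamino end, with a 2.5-fold lower number from compound 1 to compound 4 (0.39 log units; beyond the scatter). It still falls well short of the 4-methylpiperazin-1-yl end, with a 19-fold higher number from compound 2 to compound 4 (1.28 log units; beyond the scatter), so this position tolerates a ring end without a second ring nitrogen, but that end does not match the best value shown. No measurement offered here accounts for these moves.

On these data alone, each of these steps changes the ring and the chain together, so the share of each remains open. A 4-methylpiperazin-1-yl group at this three-bond position, or a 4-hydroxypiperidin-1-yl group on a longer chain, would separate them, and a plain piperidine or a morpholine would test the hydroxyl group.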